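Terpenoid quinol series: side-chain hydroxylation of compound 1

The source may report more compounds than this note shows. Statements on the series, on what has been measured and on what is new or still open speak of the compounds shown alone.

Measured so far:
compound 1 `COC1=C[C@H](O)[C@H](C/C=C(\C)CC/C=C(\C)CCC=C(C)C)[C@@H](C)C1=O`: 16400 nM
compound 2 `COC1=C(OC)[C@H](OC(C)=O)[C@H](C/C=C(\C)CC/C=C(\C)C[C@H](O)C=C(C)C)[C@@H](C)C1=O`: 20700 nM
compound 3 `COC1=C(OC)[C@H](O)[C@H](C/C=C(\C)CC/C=C(\C)CCC=C(C)C)[C@@H](C)C1=O`: 5700 nM

In a functional assay on A549 cells (Homo sapiens) for inhibition, read by sulforhodamine B assay, with a stated time of 48 h (on this read-out higher numbers stand for weaker inhibition of growth and lower numbers for stronger inhibition of growth), compound 1 stands second highest of the three numbers shown; compound 2 sits within the scatter of it, while compound 3 gives the lowest number of the set. Among the compounds with values here, the one single-point step available, a 2.9-fold lower number from compound 1 to compound 3 (0.46 log units; beyond the scatter), is modest and beyond the scatter, but it concerns the ring and not the chain.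

The step to compound 4 `COC1=C[C@H](O)[C@H](C/C=C(\C)CC/C=C(\C)C[C@H](O)/C=C(\C)CO)[C@@H](C)C1=O` alters the chain terminus: a group of 7 heavy atoms (5 carbon, 2 oxygen; no ring) in place of a group of 5 heavy atoms (5 carbon; no ring), on a saturated chain carbon bound to a double-bonded chain carbon. Within the data shown here, no measured pair isolates this change. Compound 2 carries a hydroxyl on the chain together with further changes on the ring, and its number in this assay is within the scatter of compound 1, so that pair offers no sign of a gain from chain oxygenation, though it cannot be read as a clean step. On this basis the expectation for compound 4 is a step of a 1.2-fold higher number from compound 1 to compound 4 (0.09 log units; within the scatter), that is, no change beyond the scatter, with a slight lean toward a higher number. Compound 4 is therefore estimated at 20000 nM, within 8000 nM to 50000 nM.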

Compound 4, concentration for 50% growth inhibition: > 30000 nM
Compound 4: a limit, no number; the forecaster's own chance of this, stated with the estimate: 10%; middle value at least 1.5-fold (0.17 log units) away from the limit.
By their numbers in this assay, from the lowest: compound 3; then compounds 1 and 2 (each within the scatter of the next). At a limit, above all of these: compound 4.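

In this assay compound 4 gives > 30000 nM, which is a limit of the assay and not a number. Within the data shown here, for the first time, a change at the chain terminus can be read on the unchanged core of compound 1, with 3-methylbut-2-en-1-yl replaced on a saturated chain carbon bound to a double-bonded chain carbon: an at least 1.8-fold higher number from compound 1 to compound 4 (0.26 log units; that floor lies within the scatter). This step gives no sign of a lower number from the oxygenated terminus, but its floor does not by itself separate compound 4 from compound 1, and compound 4 alone stands at a limit among the values shown: the limit of > 30000 nM in this assay, at which 1 of the 4 values shown sits.

The compounds shown leave open which of the two oxygens in the entering group bears on the result, as no compound on the core of compound 1 carries only one of them, and whether a carboxylic acid or an amine at the chain terminus would read differently. They also leave open whether the same chain terminus gives a similar result on the core of compound 3, the lowest number of the set, where a longer or shorter chain could likewise be tested.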